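Fluoro to chloro on the phenyl compound

The source may hold more compounds than are shown below. What is called first, only, known or untested is meant among the compounds shown, and "the series" means these compounds.

Measured in a functional assay on HeLa S3 cells (Homo sapiens) for cytotoxicity, read by XTT assay, with a stated time of 3 days; a higher number here means a weaker inhibitor, a lower number a stronger inhibitor:
compound 1 `OC[C@H]1O[C@@H](n2cc(F)c3c(-c4ccccc4)ncnc32)[C@H](O)[C@@H]1O`: 2600 nM
compound 2 `OC[C@H]1O[C@@H](n2cc(F)c3c(-c4ccsc4)ncnc32)[C@H](O)[C@@H]1O`: 210 nM
compound 3 `OC[C@H]1O[C@@H](n2cc(F)c3c(-c4cc[nH]c4)ncnc32)[C@H](O)[C@@H]1O`: 8900 nM

Compound 1 stands in the middle of these three numbers, with a 3.4-fold higher number from compound 1 to compound 3 (0.53 log units; beyond the scatter) as its nearest gap and a 12-fold lower number from compound 1 to compound 2 (1.09 log units; beyond the scatter) as its furthest. Compound 4 `OC[C@H]1O[C@@H](n2cc(Cl)c3c(-c4ccccc4)ncnc32)[C@H](O)[C@@H]1O` keeps the phenyl group of compound 1 but carries chloro in place of fluoro on an aromatic carbon. Going by the values given here, both of those steps replace phenyl, and no measured step replaces fluoro, so they show how far the numbers can move but give no direct measure of this change. Among the compounds with values here, the expected outcome is a 1.3-fold lower number from compound 1 to compound 4 (0.11 log units; within the scatter), with no firm direction and no large step anticipated. For compound 4 the estimate is 2000 nM, with an expected range from 500 nM to 9000 nM in this assay, kept wide for lack of direct evidence.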

Compound 4, half-maximal inhibitory concentration: 420 nM
For compound 4 the middle estimate is 4.8-fold (0.68 log units) above the measured one, outside the stated range (below it).
By their numbers in this assay, from the lowest: compounds 2 and 4 (each within the scatter of the next); then compound 1; then compound 3.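

In this assay the carbon bearing the halogen on the five-membered aromatic ring proves sensitive: with the phenyl group held constant, chloro in place of fluoro gives a 6.2-fold lower number from compound 1 to compound 4 (0.79 log units; beyond the scatter). Going by these compounds alone, this is the first measured change at this carbon, and it shows that a single halogen exchange moves the number beyond the scatter, as replacing the phenyl group did. Nothing at hand explains this shift. On these data alone, whether the thiophen-3-yl and 1H-pyrrol-3-yl compounds respond to chloro in the same way remains open. So does the outcome with bromo, methyl or an amine at this carbon.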